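Cyanophenyl quinoline series: alkoxy chain in place of halogen

A few compounds are considered here, and "the series" means these few. Any claim that something is new, unique, unknown or untested is made for them only; others in the source may bear on it.

Measured compounds:
compound 1, `Cc1ccc2ccc(-c3cc(Cl)cc(C#N)c3)cc2n1`, 1.4 nM
compound 2, `Cc1ccc2ccc(-c3cc(Br)cc(C#N)c3)cc2n1`, 13 nM

Both compounds were run in a functional assay on CHO cells for inhibition of metabotropic glutamate receptor 5 (Rattus norvegicus), read by FLIPR and calcium flux; on this read-out lower numbers stand for stronger inhibition and higher numbers for weaker inhibition. Compound 2 gives 13 nM, the higher of the two numbers; its nearest neighbour is compound 1, which gives 1.4 nM, and the one step shown, a 9.3-fold higher number from compound 1 to compound 2 (0.97 log units; beyond the scatter), is bromo in place of chloro on an aromatic carbon.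

Compound 3, `COCCOc1cc(C#N)cc(-c2ccc3ccc(C)nc3c2)c1`, is not yet measured. Its change from compound 2 is 2-methoxyethoxy in place of bromo on an aromatic carbon, so the position that carried the halogens now carries a chain of five heavy atoms with two hydrogen-bond acceptors.

Among the compounds with values here, only the step from compound 1 to compound 2 bears on this position, and it exchanges one halogen for another; no measured pair covers an alkoxy chain here. That step already moved the number beyond the scatter, so the position is sensitive. A larger group entering there is expected to shift the number further in the same direction, with wide uncertainty: the expected step is a 3.1-fold higher number from compound 2 to compound 3 (0.49 log units; beyond the scatter). Compound 3 is therefore estimated at 40 nM, within 8 nM to 200 nM.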

Compound 3, half-maximal inhibitory concentration: 82 nM
For compound 3 the middle estimate is 2.1-fold (0.31 log units) below the measured one, within the range that was stated.
By their numbers in this assay, from the lowest: compound 1; then compound 2; then compound 3.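

In this assay, the place meta to a cyano group still gives a measurable number with a chain on it, but inhibition weakens further than it did with the halogen exchange: 2-methoxyethoxy in place of bromo gives a 6.3-fold higher number from compound 2 to compound 3 (0.80 log units; beyond the scatter), and 2-methoxyethoxy in place of chloro gives a 59-fold higher number from compound 1 to compound 3 (1.77 log units; beyond the scatter). Within the data shown here, the second of these steps is the largest so far, so the sensitivity seen between the two halogens extends to a non-halogen group, and chloro remains the substituent with the lowest number of the three; because the chain's 5 heavy atoms and 2 hydrogen-bond acceptors enter together, these compounds cannot separate the two. No supporting data bear on the reason for the size of these steps.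

The compounds shown leave open whether the rise in the number follows chain length or the ether oxygens, which a methoxy group, a propyl chain or a longer ether chain at the same place would help separate. Also open, from the compounds shown here alone, is how a chain ending in an amine or a carboxylic acid would read here.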